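The compounds below may be only part of what the source reports. "The series", "measured", "known", "first", "only" and "open" are said of these compounds alone.

Compound 2 `COn1c(-c2ccccc2)c(Br)c2cc(C#N)c(C#N)cc21` stands at the edge of what the numbers can say: in an assay on isolated protein for inhibition of Amine oxidase [flavin-containing] B (Homo sapiens), read by fluorescence and spectrophotometry, with a stated time of 20 min (a higher number here means a weaker inhibitor, a lower number a stronger inhibitor), compound 2 gives > 100000 nM, which is a limit of the assay rather than a measured number, the same edge as the limit of > 100000 nM in this assay, at which 1 of the 2 values shown sits. Compound 1 `COn1c(-c2ccc(C)cc2)c(C=O)c2cc(C#N)c(C#N)cc21` has a measured value: in this assay compound 1 gives 74800 nM. Compound 3 `COn1c(-c2ccc(C)cc2)c(Br)c2cc(C#N)c(C#N)cc21` differs from compound 2 by methyl in place of hydrogen on an aromatic carbon. No measured step of this kind is shown here, so the expected step is a number no higher from compound 2 to compound 3 (the limit leaves the size open), nothing beyond the usual scatter. Compound 3 is therefore estimated at about 100000 nM, in a range from 40000 nM to 250000 nM.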

Compound 3, half-maximal inhibitory concentration: 7460 nM
For compound 3 the middle estimate is 13-fold (1.13 log units) above the measured one; the whole stated range lies above it.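

Adding one methyl to the phenyl ring while keeping the bromo gives an at least 13-fold lower number from compound 2 to compound 3 (1.12 log units; beyond the scatter) and shows that this position responds strongly to a very small change. Going by these compounds, compound 2 stands at a limit of the assay, so the full size of that step is unknown: the limit of > 100000 nM in this assay, at which 1 of the 3 values shown sits. With the 4-methylphenyl kept, bromo in place of formyl gives a 10-fold lower number from compound 1 to compound 3 (1.00 log units; beyond the scatter) and shows that this second position also matters. On these data alone, whether an ethyl, a methoxy or an amine in the methyl's place would do better remains open, as does the effect of the same methyl when formyl replaces bromo.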